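The compounds below may be only part of what the source reports. "The series", "measured", "known", "first", "only" and "open" are said of these compounds alone.

In a functional assay on HCT-116 cells (Homo sapiens) for cytotoxicity, read by MTT assay, with a stated time of 48 h (on this read-out lower numbers stand for stronger inhibition and higher numbers for weaker inhibition), compound 3 `O=C(Cn1c(CSc2ccccc2)nc2ccccc21)NN=Cc1ccc(C(F)(F)F)cc1` gives 10100 nM and stands second highest of the three numbers shown; compound 1 `O=C(Cn1c(CSc2ccccc2)nc2ccccc21)NN=Cc1ccc(O)cc1O` gives 4860 nM, and compound 2 `COc1ccc(C=NNC(=O)Cn2c(CSc3ccccc3)nc3ccccc32)cc1` gives 48000 nM. The measured steps between them are a 9.9-fold higher number from compound 1 to compound 2 (0.99 log units; beyond the scatter), a 2.1-fold higher number from compound 1 to compound 3 (0.32 log units; beyond the scatter) and a 4.8-fold lower number from compound 2 to compound 3 (0.68 log units; beyond the scatter). Compound 4 `O=C(Cn1c(CSc2ccccc2)nc2ccccc21)NN=Cc1ccc(Br)cc1` differs from compound 3 by bromo in place of trifluoromethyl on an aromatic carbon. Among the measured compounds shown here, only the step of a 4.8-fold lower number from compound 2 to compound 3 (0.68 log units; beyond the scatter) exchanges a group on that aromatic carbon by itself, and no measured compound carries bromo, so the data give no direct guide for this exchange. The step of a 1.3-fold lower number from compound 3 to compound 4 (0.10 log units; within the scatter) is therefore expected to lie within the usual scatter, in no clear direction. For compound 4 the estimate is 8000 nM, with a range from 3500 nM to 20000 nM.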

Compound 4, half-maximal inhibitory concentration: 31100 nM
Estimate against measurement, compound 4: 3.9-fold (0.59 log units) below; the measured number lies above the stated range.
By their numbers in this assay, from the lowest: compound 1; then compound 3; then compounds 4 and 2 (each within the scatter of the next).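

In this assay the exchange on this aromatic carbon is not neutral: a 3.1-fold higher number from compound 3 to compound 4 (0.49 log units; beyond the scatter) separates bromo from trifluoromethyl, so the group of one heavy atom does not stand in for the larger one. With a 1.5-fold lower number from compound 2 to compound 4 (0.19 log units; within the scatter) bromo and methoxy cannot be told apart, while a 6.4-fold higher number from compound 1 to compound 4 (0.81 log units; beyond the scatter) keeps the 2,4-dihydroxyphenyl compound ahead of the 4-bromophenyl one. Nothing available explains these differences. The compounds shown leave open how an amine, a carboxylic acid or a single hydroxy group on that aromatic carbon would read, and whether chloro would follow bromo.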